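The compounds below may be only part of what the source reports. "The series", "measured", "known", "first", "only" and "open" are said of these compounds alone.

In an ADME assay on MT4 cells (Homo sapiens) for cytotoxicity, read by spectrophotometry, with a stated time of 5 days (on this read-out lower numbers stand for higher toxicity in this test and higher numbers for lower toxicity in this test), compound 2 (`COc1ccc(N2CCN(CN3C(=O)/C(=N\NC(=S)NO)c4cc(F)ccc43)CC2)cc1`) gives 260000 nM among the three measured compounds. Compound 1 (`O=C1/C(=N\NC(=S)NO)c2cc(F)ccc2N1CN1CCN(c2ccc(Cl)cc2)CC1`) gives 194000 nM in the same test, a number within the scatter of compound 2, whereas compound 3 (`CONC(=S)N/N=C1\C(=O)N(CN(C)C)c2ccc(C)cc21`) gives 622000 nM as a number that lies higher than that of compound 2, beyond the scatter. Compound 3 differs from compound 2 in more than one place, so it offers no clean comparison.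

Compound 4 (`COc1ccc(N2CCN(CN3C(=O)/C(=N\NC(=S)NO)c4cc(Cl)ccc43)CC2)cc1`) departs from compound 2 by a single exchange on the shared core, chloro in place of fluoro on an aromatic carbon and nothing else. For the measured compounds named here, no measured pair shows this exchange itself. Going by the values given here, only one measured step bears on it, and only loosely: methoxy in place of chloro on an aromatic carbon, in another part of the structure, gave a 1.3-fold higher number from compound 1 to compound 2 (0.13 log units; within the scatter) and so stayed within the scatter. On that slim evidence, no step beyond the scatter is expected in this assay for the new exchange. The estimated change is a 1.1-fold lower number from compound 2 to compound 4 (0.05 log units; within the scatter) and is expected to stay within the scatter. For compound 4 the expected value is 230000 nM with an estimated range from 120000 nM to 450000 nM in this test.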

Compound 4, half-maximal cytotoxic concentration: 279000 nM
For compound 4 the middle estimate is 1.2-fold (0.08 log units) below the measured one; the range from low to high includes it.
By their numbers in this assay, from the lowest: compounds 1, 2 and 4 (each within the scatter of the next); then compound 3.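

In this assay, for the compounds shown here, the exchange of fluoro for chloro on an aromatic carbon of the shared core gave a 1.1-fold higher number from compound 2 to compound 4 (0.03 log units; within the scatter), the first direct reading at this position, which lies on a six-membered aromatic ring of carbon only, part of a fused or bridged system of two rings. The earlier compounds shown here spoke only to another part of the structure, where methoxy in place of chloro gave a 1.3-fold higher number from compound 1 to compound 2 (0.13 log units; within the scatter), so in these two single exchanges, one in each place, neither step left the scatter. No measurement shown here offers an explanation for the outcome at this position.

Going by these compounds, this reading rests on a single pair of halogens carrying the methoxy-substituted aromatic ring, so it remains open whether an amine or a carboxylic acid on the same aromatic carbon would move the number beyond the scatter. On these data alone, it also remains open which of the several differences in compound 3 goes with its higher number, and whether the exchange of fluoro for chloro would give a similar step in a compound carrying chloro in place of that methoxy.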